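Oxygen to Sulfur on the Dichlorophenyl Arm

This account rests on a few compounds, and the source may have more. Where it says the series, first, only, none or still open, it means among the compounds named here.

Compound 1 `Nc1cc(N)c2nc(-c3ccccc3)c(Oc3ccc(Cl)c(Cl)c3)nc2c1` carries a 3,4-dichlorophenoxy group on a shared core. In a functional assay on HCT-116 cells (Homo sapiens) for inhibition, read by sulforhodamine B assay, with a stated time of 48 h (on this read-out higher numbers stand for weaker inhibition of growth and lower numbers for stronger inhibition of growth), compound 1 gives 15800 nM. Two related compounds have been measured in the same way: compound 2 `CCOC(=O)[C@H](CCC(=O)O)NC(=O)c1ccc(Sc2nc3cc(N)cc(N)c3nc2-c2ccccc2)cc1` gives 21400 nM in this assay, and compound 3 `CCOC(=O)[C@H](CCC(=O)O)NC(=O)c1ccc(Oc2nc3cc(N)cc(N)c3nc2-c2ccccc2)cc1` gives 15100 nM. Among these three numbers compound 1 stands second highest; its nearest neighbour is compound 3, and even the furthest, compound 2, lies within the usual scatter, so the three compounds cannot be told apart on this read-out.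

Compound 4 `Nc1cc(N)c2nc(-c3ccccc3)c(Sc3ccc(Cl)c(Cl)c3)nc2c1` has not yet been measured. It differs from compound 1 in one place: (3,4-dichlorophenyl)sulfanyl in place of 3,4-dichlorophenoxy on an aromatic carbon. The same exchange of sulfur for oxygen separates compound 3 from compound 2, and there compound 3 gives 15100 nM while compound 2 gives 21400 nM, two values that sit within the scatter of each other. On that basis the step from oxygen to sulfur is expected to be a 1.1-fold higher number from compound 1 to compound 4 (0.06 log units; within the scatter), a change no larger than the scatter and without a clear direction. Compound 4 is therefore estimated at 18000 nM, with a likely range from 8000 nM to 45000 nM.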

Compound 4, concentration for 50% growth inhibition: 9330 nM
Compound 4: the middle estimate sits 1.9-fold (0.29 log units) above what was measured; low and high end bracket the measured number.
By their numbers in this assay, from the lowest: compounds 4, 3, 1 and 2 (each within the scatter of the next, the first and the last beyond it).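

Among the compounds shown here, this pair gives the first direct reading of the exchange on the 3,4-dichlorophenyl arm, where the sulfanyl link replaces the phenoxy oxygen on the same aromatic carbon, and in this assay the result is (a 1.7-fold lower number from compound 1 to compound 4 (0.23 log units; within the scatter)). With the ring and its two chlorines unchanged, the linking atom at this position can therefore be exchanged without a change in growth inhibition that stands clear of the scatter, so no preference for oxygen or sulfur can be stated here. Nothing measured here explains the size or the direction of this step.

The compounds shown leave open whether a different link at this aromatic carbon, such as an amine nitrogen or a methylene group, would separate itself from the oxygen and sulfur compounds. They also leave open whether replacing the two chlorines on the ring with other groups, such as methoxy or trifluoromethyl, would move the number beyond the scatter, and whether the choice of oxygen or sulfur would then begin to matter.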